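A few compounds are considered here, and "the series" means these few. Any claim that something is new, unique, unknown or untested is made for them only; others in the source may bear on it.

Compound 3 `CCCCCCCCc1ccc(OCC(=O)COc2ccc3c(c2)cc(C(=O)O)n3CC(=O)O)cc1` carries a carboxymethyl group on the aromatic nitrogen of the shared core. Among the compounds with values here, in a physicochemical assay for solubility, in phosphate buffer, at pH 7.4 (a lower number here means a less soluble compound, a higher number a more soluble compound), compound 3 gives 8.1 ug/mL, one of only two numbers reported, the other belonging to compound 1 `CCCCCCCCc1ccc(OCC(=O)COc2ccc3[nH]c(C(=O)O)cc3c2)cc1` and sitting within the scatter of it: in this assay compound 1 gives 8.4 ug/mL. Compound 2 `CCCCCCCCc1ccc(OCC(=O)COc2ccc3c(c2)cc(C(=O)O)n3CCC)cc1`, with propyl on that nitrogen, reached only a limit of the assay. In this assay compound 2 gives < 1 ug/mL, a limit and not a number (the limit of < 1 ug/mL in this assay, at which 1 of the 3 values shown sits). Compound 4 `CCCCCCCCc1ccc(OCC(=O)COc2ccc3c(c2)cc(C(=O)O)n3Cc2ccc(C(=O)O)cc2)cc1` differs from compound 3 by 4-carboxyphenyl in place of carboxy on a saturated chain carbon bound to an aromatic nitrogen. Within the data shown here, two measured steps bear on this change. The step of a 1.0-fold lower number from compound 1 to compound 3 (0.02 log units; within the scatter) shows that the carboxymethyl group left the number where it stood. The step of an at least 8.4-fold lower number from compound 1 to compound 2 (0.92 log units; beyond the scatter) went beyond the scatter, and the step of an at least 8.1-fold higher number from compound 2 to compound 3 (0.90 log units; beyond the scatter) brought the number back. The change to compound 4 keeps the carboxy group but adds a six-membered aromatic ring of carbon only on the saturated chain carbon bound to the aromatic nitrogen, an addition of carbon in the manner of the propyl of compound 2. One therefore expects a step of a 4.1-fold lower number from compound 3 to compound 4 (0.61 log units; beyond the scatter), a lower number beyond the scatter. Compound 4 is estimated at 2 ug/mL, in a range from 0.5 ug/mL to 8 ug/mL.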

Compound 4, solubility: 13 ug/mL
Compound 4: middle estimate off by 6.5-fold (0.81 log units), on the low side, and the stated range ends below it.
By their numbers in this assay, from the lowest: compounds 3, 1 and 4 (each within the scatter of the next). At a limit, below all of these: compound 2.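

Going from carboxymethyl to 4-carboxybenzyl on the aromatic nitrogen gave a 1.6-fold higher number from compound 3 to compound 4 (0.21 log units; within the scatter), and hydrogen giving way to 4-carboxybenzyl gave a 1.5-fold higher number from compound 1 to compound 4 (0.19 log units; within the scatter), so in this assay the added six-membered aromatic ring of carbon only did not by itself take the number beyond the scatter, as the propyl comparison had suggested it might. The propyl and 4-carboxyphenyl groups on the saturated chain carbon bound to the aromatic nitrogen are set far apart by an at least 13-fold higher number from compound 2 to compound 4 (1.11 log units; beyond the scatter), which shows that added carbon at this position can go either way among the listed compounds. That step starts from compound 2, whose entry is a limit and not a number: the limit of < 1 ug/mL in this assay, at which 1 of the 4 values shown sits.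

A plain benzyl group on the aromatic nitrogen is not among the compounds shown, nor is an amine in place of the carboxy group on the ring, so what that carboxy group contributes on its own remains open. Also open, as far as these compounds go, is how the number would respond to a longer chain between the aromatic nitrogen and the carboxylic acid.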